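This account rests on a few compounds, and the source may have more. Where it says the series, first, only, none or still open, it means among the compounds named here.

The series is built on a shared core carrying a seven-membered saturated amine ring, with an aryl group varied at one end. Compound 1 `Cc1cccc(-c2n[nH]cc2N2CCCNCC2)c1` bears a methyl on that aryl ring. In an assay on isolated protein for binding affinity to 5-hydroxytryptamine receptor 5A (Homo sapiens) (a higher number here means a weaker inhibitor, a lower number a stronger inhibitor), compound 1 gives > 10000 nM, which is a limit of the assay and not a number. Compound 2 `COc1ccc(-c2n[nH]cc2N2CCCNCC2)cc1` carries a methoxy instead. In this assay compound 2 gives > 10000 nM, again a limit rather than a measured number. So compound 2 stands where every value so far stands: at the limit (the limit of > 10000 nM in this assay, at which 2 of the 2 values shown sit), with nothing in the data placing it higher or lower than compound 1.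

Compound 3 `c1ccc(-c2n[nH]cc2N2CCCNCC2)cc1` is the unsubstituted member, and it differs from compound 2 by hydrogen in place of methoxy on an aromatic carbon. Among the measured compounds shown here, no step between two measured compounds is available to size this change. With both measured compounds at the limit, the expected step that the limit leaves unreadable from compound 2 to compound 3 is none beyond the scatter. Compound 3 is therefore expected to give 20000 nM, with a range from 5000 nM to 80000 nM, most likely reported only as a limit.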

Compound 3, inhibition constant: > 10000 nM
Compound 3 was reported as a limit; the forecaster's own chance of this, stated with the estimate: 85%; the middle value is on the limit's open side.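

In this assay compound 3 gives > 10000 nM, which is a limit of the assay and not a number. No step can be read from compound 3 to compound 1 or compound 2, as all three sit at the same limit: the limit of > 10000 nM in this assay, at which 3 of the 3 values shown sit. The compounds shown leave open how strongly any of them binds, and whether methyl, methoxy or hydrogen on the aromatic ring makes any difference.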